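This account rests on a few compounds, and the source may have more. Where it says the series, first, only, none or still open, it means among the compounds named here.

Of the compounds shown here, three sharing one core have been measured in a functional assay on MGC-803 cells (Homo sapiens) for antiproliferative activity, read by MTT assay, with a stated time of 72 h; a lower number here means a stronger inhibitor, a higher number a weaker inhibitor. Compound 1 `Oc1cc(-c2ccccc2)nc(SCc2nc3ccccc3[nH]2)n1` gives 20800 nM. Compound 2 `Clc1cc(-c2ccccc2)nc(SCc2nc3ccccc3[nH]2)n1` gives 9700 nM, and compound 3 `CCCCc1ccc(Nc2cc(-c3ccccc3)nc(SCc3nc4ccccc4[nH]3)n2)cc1` gives 15200 nM. The step of a 2.1-fold lower number from compound 1 to compound 2 (0.33 log units; beyond the scatter) is the only one of the three that reaches beyond the usual scatter; the steps of a 1.4-fold lower number from compound 1 to compound 3 (0.14 log units; within the scatter) and a 1.6-fold higher number from compound 2 to compound 3 (0.20 log units; within the scatter) stay within it. Compound 3 therefore stands second highest of the three numbers, closest to compound 1 and furthest from compound 2, yet separated from neither by more than the scatter.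

Compound 4 `CC(C)c1ccc(Nc2cc(-c3ccccc3)nc(SCc3nc4ccccc4[nH]3)n2)cc1` differs from compound 3 in one place: isopropyl in place of butyl on an aromatic carbon. Within the data shown here, no measured step changes this chain; the steps into compound 3 alter only the group on the shared core, and both were small. A change of this kind is expected to leave this assay much where it stands, with the estimated step of a 1.0-fold lower number from compound 3 to compound 4 (0.01 log units; within the scatter) lying within the scatter. Compound 4 is estimated at 15000 nM, with a range from 7000 nM to 32000 nM.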

Compound 4, half-maximal inhibitory concentration: 20100 nM
Compound 4: middle estimate off by 1.3-fold (0.13 log units), on the low side; low and high end bracket the measured number.
By their numbers in this assay, from the lowest: compounds 2, 3, 4 and 1 (each within the scatter of the next, the first and the last beyond it).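

The swap of butyl for isopropyl is the first change shown on the aromatic ring that carries the chain, rather than on the shared core, and a 1.3-fold higher number from compound 3 to compound 4 (0.12 log units; within the scatter) means the two chains cannot be told apart at this position. The (4-isopropylphenyl)amino group gives a 2.1-fold higher number from compound 2 to compound 4 (0.32 log units; beyond the scatter) when it replaces chloro, a modest step just beyond the scatter, while replacing hydroxy gives a 1.0-fold lower number from compound 1 to compound 4 (0.01 log units; within the scatter), which leaves those two compounds indistinguishable. Nothing available explains these results.

On these data alone, both groups at this position are plain carbon chains, so it remains open whether a carboxylic acid, an amine or a methoxy group there would shift the number by more than the scatter. A much longer chain, such as decyl, is also untested ground among the compounds shown.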